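The source may report more compounds than this note shows. Statements on the series, on what has been measured and on what is new or still open speak of the compounds shown alone.

In an assay on HEK293 cells for displacement of a labelled ligand from Melanocortin receptor 4 (Homo sapiens) (a higher number here means a weaker inhibitor, a lower number a stronger inhibitor), the two measured compounds give:

compound 1, `CC(C)C[C@H](N)c1cc(C(F)(F)F)ccc1N1CCN(C(=O)C(C)Cc2ccc(Cl)cc2O)CC1`: 36 nM
compound 2, `CC(C)C[C@H](N)c1ccccc1N1CCN(C(=O)[C@H](C)Cc2ccc(Cl)cc2Cl)CC1`: 16 nM

Compound 1 has the higher of these two numbers. The gap from compound 2 to compound 1 lies beyond the scatter of repeated measurements, but the two structures differ in more than one place, so no single change can be tied to that gap.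

Compound 3, `Cc1cc(CC(C)C(=O)N2CCN(c3ccc(C(F)(F)F)cc3[C@@H](N)CC(C)C)CC2)ccc1Cl`, has not been measured. Its structure follows from compound 1 by one change, counted here:

4-chloro-3-methylphenyl in place of 4-chloro-2-hydroxyphenyl on a saturated chain carbon, two bonds along the chain from a carbonyl carbon

The hydroxyl, the only hydrogen-bond donor and acceptor of the leaving group, disappears, and a methyl arrives at a different position of the ring; the chlorine stays. Among the compounds with values here, no measured pair shows this change on its own, so its effect must be guessed. The expected step is a 1.4-fold higher number from compound 1 to compound 3 (0.14 log units; within the scatter), a small one and not clearly beyond the scatter in either direction. Compound 3 is therefore expected to give about 50 nM in this assay. The estimate for compound 3 spans from 15 nM to 160 nM.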

Compound 3, inhibition constant: 71 nM
The estimate for compound 3 lay 1.4-fold (0.15 log units) below the measured number; the range from low to high includes it.
By their numbers in this assay, from the lowest: compound 2; then compounds 1 and 3 (each within the scatter of the next).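

In this assay, putting 4-chloro-3-methylphenyl in place of 4-chloro-2-hydroxyphenyl on the saturated chain carbon gives a 2.0-fold higher number from compound 1 to compound 3 (0.29 log units; within the scatter), so this measurement does not separate the two compounds. The leaving group counts 1 hydrogen-bond donor and 1 hydrogen-bond acceptor and the entering group counts 0 of each, yet the step stays within the scatter, so in this pair the hydroxyl is not shown to be needed for displacing the labelled ligand. No measurement at hand speaks to why the step has this size.

On these data alone, this single change removes the hydroxyl and adds the methyl at once, so the contribution of each one alone stays open, and a small effect from one could be offset by the other. Whether a plain 4-chlorophenyl, which carries neither group, or a 4-chloro-2-methoxyphenyl, which keeps an oxygen at the place of the hydroxyl but loses its hydrogen, would also stay within the scatter of compound 1 is a question these compounds cannot answer.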